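A benzoyl swap in a series held at its limit

A few compounds are considered here, and "the series" means these few. Any claim that something is new, unique, unknown or untested is made for them only; others in the source may bear on it.

In a functional assay on HepG2 cells (Homo sapiens) for inhibition, read by MTT assay, with a stated time of 48 h (a lower number here means a stronger inhibitor, a higher number a weaker inhibitor), the measured compounds read as follows, and each entry is a limit, not a number:
compound 1 (`COc1cc(-c2nnc(SC)n2-c2ccc(N(C)C)cc2)cc(OC)c1OC`) gives > 60000 nM as a limit
compound 2 (`COc1ccc(CSc2nnc(-c3cc(OC)c(OC)c(OC)c3)n2-c2ccc(N(C)C)cc2)cc1`) gives > 60000 nM as a limit
compound 3 (`COc1cc(-c2nnc(SCc3ccc(C)cc3)n2-c2ccc(N(C)C)cc2)cc(OC)c1OC`) gives > 60000 nM as a limit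

Compound 3 therefore has no number of its own, only this limit (> 60000 nM). Compound 4 (`COc1cc(-c2nnc(SCC(=O)c3ccccc3)n2-c2ccc(N(C)C)cc2)cc(OC)c1OC`) keeps the core of compound 3 and carries benzoyl in place of 4-methylphenyl on a saturated chain carbon bound to a sulfur. In other words, (4-methylbenzyl)sulfanyl gives way to (benzoylmethyl)sulfanyl.

Within the data shown here, three measured steps bear on this change: a step that the two limits leave unreadable from compound 1 to compound 2 and a step that the two limits leave unreadable from compound 1 to compound 3 and a step that the two limits leave unreadable from compound 2 to compound 3 and none of them has a size that can be read. What remains is the limit of > 60000 nM in this assay, at which 3 of the 3 values shown sit, and it gives no direction for the new group. No step beyond the scatter can therefore be forecast in this assay and compound 4 is expected to remain near the same limit, quite possibly reported only as a limit. The expected change is a number no higher from compound 3 to compound 4 (the limit leaves the size open) as an estimate only. The estimate for compound 4 is 60000 nM (expected range 20000 nM to 120000 nM).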

Compound 4, half-maximal inhibitory concentration: 18900 nM
For compound 4 the middle estimate is 3.2-fold (0.50 log units) above the measured one; measured number outside the range, below it.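

In this assay, the position on a saturated chain carbon bound to a sulfur now gives its first readable response, as benzoyl there produces an at least 3.1-fold lower number from compound 3 to compound 4 (0.50 log units; beyond the scatter), and the same group gives an at least 3.1-fold lower number from compound 2 to compound 4 (0.50 log units; beyond the scatter) and an at least 3.1-fold lower number from compound 1 to compound 4 (0.50 log units; beyond the scatter). The steps among compound 1, compound 2 and compound 3 cannot be read, so hydrogen, 4-methoxyphenyl and 4-methylphenyl could not show that this position responds at all. Among the groups shown, only benzoyl, the one that brings a carbonyl and a hydrogen-bond acceptor, yields a number, while compound 1, compound 2 and compound 3 each remain at a limit and not a number: the limit of > 60000 nM in this assay, at which 3 of the 4 values shown sit.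

As far as these compounds go, the true size of the step stays open, since each of these comparisons starts from a limit, and the change from compound 3 to compound 4 both brings in the carbonyl and removes the ring methyl. A 4-methylbenzoyl group at this position would separate those two changes, and a carboxylic acid or an amide in place of the phenyl ketone would test whether the aromatic ring is needed at all.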